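Swapping a methoxyphenyl for a pyridine on a pyrrole nitrogen

This account rests on a few compounds, and the source may have more. Where it says the series, first, only, none or still open, it means among the compounds named here.

Among the measured compounds shown here, compound 1, with the structure `CCOC(=O)C1=C(C)N/C(=C/c2cc(C)n(-c3ccc(OC)cc3)c2C)C1=O`, is the only member of this small set for which a number exists. In a physicochemical assay for lipophilicity, read by HPLC, at pH 7.4 (a lower number here means a more polar compound, a higher number a more lipophilic compound), compound 1 gives 3, which places it as the sole reference point. Two relatives share the same core: compound 2, `CCOC(=O)C1=C(C)N/C(=C/c2cc(C)n(-c3ccc(SC(F)(F)F)cc3)c2C)C1=O`, and compound 3, `CCOC(=O)C1=C(C)N/C(=C/c2cc(C)n(-c3ccc(S(=O)(=O)C(F)(F)F)cc3)c2C)C1=O`. In this assay compound 2 gives "not determined" (no result reported). In this assay compound 3 gives "not determined" (no result reported). For compound 2 and compound 3 no result was reported in this assay, so nothing can be said about how they compare with compound 1.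

The compound yet to be measured is compound 4, `CCOC(=O)C1=C(C)N/C(=C/c2cc(C)n(-c3ccncc3)c2C)C1=O`. Its structure differs from compound 1 in a single place: pyridin-4-yl in place of 4-methoxyphenyl on an aromatic nitrogen, on an aromatic nitrogen of a five-membered aromatic ring with 1 nitrogen, next to two ring atoms that each bear a methyl group.

For the measured compounds named here, since no measured pair of this kind is at hand, the expected step from compound 1 to compound 4 in this assay is estimated as a number 1.30 log units lower from compound 1 to compound 4 (beyond the scatter), a fall clearly beyond the usual scatter. For compound 4 the expected value in this assay is therefore 1.7, within a range from 1.2 to 2.3.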

Compound 4, distribution coefficient: 3.2
For compound 4 the middle estimate is 1.50 log units below the measured one; measured number outside the range, above it.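

In this assay, putting pyridin-4-yl in place of 4-methoxyphenyl on an aromatic nitrogen gives a number 0.20 log units higher from compound 1 to compound 4 (within the scatter), so this one exchange cannot be told apart from repeat-measurement noise in this read-out. Among the compounds shown here, this is the first measured step at this position, and it shows that a six-membered aromatic ring with 1 hetero atom and a smaller group of 6 heavy atoms can take the place of the 8-atom 4-methoxyphenyl with no detectable difference between the two compounds. Nothing shown here gives a reason for this result.

Steps involving compound 2 and compound 3 cannot be read, so this single pair is all there is to go on at this position. On these data alone, whether a phenyl ring carrying a carboxylic acid or an amine would read alike on this nitrogen stays open.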